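A few compounds are considered here, and "the series" means these few. Any claim that something is new, unique, unknown or untested is made for them only; others in the source may bear on it.

Measured compounds:
Compound 1, `Cc1coc2cc(OCC(=O)Nc3cccc(NC(=O)c4ccc(N(C)C)cc4)c3)ccc2c1=O`: in an assay on isolated protein for inhibition of Rho-associated protein kinase 1 (Homo sapiens), read by scintillation counting, radiometric assay and 33P incorporation, with a stated time of 40 min, in the presence of a further agent that is not named here (a higher number here means a weaker inhibitor, a lower number a stronger inhibitor), compound 1 gives > 10000 nM, which is a limit of the assay rather than a number.
Compound 2, `Cc1ccc(C(=O)Nc2cccc(NC(=O)COc3ccc4c(=O)ccoc4c3)c2)cc1`: in this assay compound 2 gives 183 nM.

Among the compounds with values here, compound 2 stands as the only compound with a numerical result in this assay. The other result shown is a limit (the limit of > 10000 nM in this assay, at which 1 of the 2 values shown sits).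

Compound 3, `O=C(COc1ccc2c(=O)ccoc2c1)Nc1cccc(NC(=O)c2ccc(Br)cc2)c1`, has not yet been measured in this assay. It differs from compound 2 by bromo in place of methyl on an aromatic carbon. Within the data shown here, no pair of measured compounds shows this change, so there is no measured step to lean on. Swapping one small substituent for another is expected to move the result little: the step of a 1.1-fold higher number from compound 2 to compound 3 (0.04 log units; within the scatter) is expected to be none beyond the usual scatter. Compound 3 is therefore estimated at 200 nM in this assay, with a likely range from 70 nM to 600 nM.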

Compound 3, half-maximal inhibitory concentration: 303 nM
Compound 3: middle estimate off by 1.5-fold (0.18 log units), on the low side, and the stated range covers the measured number.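

The exchange of 4-methylphenyl for 4-bromophenyl gives the first step measured at this position: a 1.7-fold higher number from compound 2 to compound 3 (0.22 log units; within the scatter) in this assay. Within the data shown here, it shows that, on this ring and para to a large group, bromo and methyl give results within the usual scatter of each other, which the earlier compounds could not show because they differ in more than one place. Nothing shown here gives a cause for this step.

Both groups compared are single heavy atoms without hydrogen-bond donors or acceptors, so the step says nothing about how an amine, a carboxylic acid or a longer chain at this place would read in this assay. It also leaves open whether bromo in place of methyl would give a similar step on any other ring of these compounds.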